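Cyclohexyl for 3-ethylphenyl on the amide nitrogen

The source may hold more compounds than are shown below. What is called first, only, known or untested is meant among the compounds shown, and "the series" means these compounds.

Of the compounds shown here, three sharing one core have been measured in a functional assay on HEK293 cells for agonist activity at D(4) dopamine receptor (Homo sapiens), read by FLIPR; a lower number here means a smaller maximal response, a higher number a larger maximal response. Compound 1 `CCc1cccc(NC(=O)CN2CCC(c3cccc[n+]3[O-])CC2)c1` gives 62% in this assay. Compound 3 `Cc1cccc(Cl)c1NC(=O)CN1CCC(c2ccccn2)CC1` gives 70%, a number within the scatter of compound 1, so the two cannot be told apart. Compound 2 `O=C(CN1CCC(c2ccccn2)CC1)Nc1c(Cl)cc(Cl)cc1Cl` gives 45%, which lies beyond the scatter below compound 1. Compound 1 therefore stands second highest of the three numbers, close to compound 3 and clearly above compound 2.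

Compound 4 `O=C(CN1CCC(c2cccc[n+]2[O-])CC1)NC1CCCCC1` has not been measured. It differs from compound 1 in one place: cyclohexyl in place of 3-ethylphenyl on an amide-type nitrogen. Within the data shown here, no measured pair shows this change, so its effect in this assay is unknown. Given the spread among the measured compounds, the step from an aromatic to a saturated ring at this place is expected to lower the maximal response moderately, by about a number 12 percentage points lower from compound 1 to compound 4 (beyond the scatter), though a result within the scatter of compound 1 would not be surprising. Compound 4 is therefore expected to give about 50% in this assay, with a likely range from 30% to 70%.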

Compound 4, largest response reached (reported as efficacy), in percent of the reference or control that the assay uses: 58%
For compound 4 the middle estimate is 8 percentage points below the measured one; low and high end bracket the measured number.
By their numbers in this assay, from the lowest: compound 2; then compounds 4, 1 and 3 (each within the scatter of the next, the first and the last beyond it).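

In this assay, putting cyclohexyl in place of 3-ethylphenyl on the amide-type nitrogen gives a number 4 percentage points lower from compound 1 to compound 4 (within the scatter) and so leaves the maximal response of compound 4 indistinguishable from that of compound 1. Among these compounds, this is the first pair that differs in only one place, and it shows that, on the core of compound 1, a six-membered aromatic ring at this position is not needed for a maximal response of this size. Nothing at hand accounts for this result.

Going by these compounds, it remains open whether any ring is needed on this nitrogen, or whether a plain butyl chain, or a cyclohexyl carrying an amine or a carboxylic acid, would read the same. This single pair also cannot say whether the same exchange would hold on a different core.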